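Sulfonamide variation in a piperidine amide M5 modulator series

The source may report more compounds than this note shows. Statements on the series, on what has been measured and on what is new or still open speak of the compounds shown alone.

Measured so far:
- compound 1, `CCN(Cc1ccccc1)C(=O)C1CCN(S(=O)(=O)c2ccc(C)s2)CC1`, 64% in a functional assay on CHO cells for positive allosteric modulation of muscarinic acetylcholine receptor M5 (Homo sapiens), read by calcium flux; on this read-out higher numbers stand for larger maximal responses and lower numbers for smaller maximal responses
- compound 2, `CCN(Cc1ccccc1)C(=O)C1CCN(S(=O)(=O)c2cccnc2)CC1`, "not determined" (no result reported) in this assay

Among the measured compounds shown here, compound 2 stands without a number in this assay; no result was reported for it, so it cannot be placed against compound 1, and no step from it can be sized.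

Compound 3, `CCN(Cc1ccccc1)C(=O)C1CCN(S(=O)(=O)c2ccc3nsnc3c2)CC1`, differs from compound 2 by the change a group of 9 heavy atoms (6 carbon, 2 nitrogen, 1 sulfur; one five-membered aromatic ring with 3 hetero atoms, one six-membered aromatic ring of carbon only) in place of a group of 6 heavy atoms (5 carbon, 1 nitrogen; one six-membered aromatic ring with 1 hetero atom), on a sulfonyl sulfur on the sulfonyl sulfur. With no value for compound 2, the size and direction of this step in this assay cannot be drawn from the data; nothing beyond the scatter can be claimed either way.

For the measured compounds named here, the only anchor is compound 1, which gives 64% in this assay with a different sulfonyl substituent on the same core. Compound 3 is therefore expected near that level, estimated at 60% in this assay, within a range of 30% to 90%.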

Compound 3, largest response reached (reported as percent of maximum), in percent of the reference or control that the assay uses: 81%
Estimate against measurement, compound 3: 21 percentage points below; measured number inside the range.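

In this assay the sulfonyl sulfur accepts a group of 9 heavy atoms in place of a group of 6 heavy atoms, with a number 17 percentage points higher from compound 1 to compound 3 (beyond the scatter) and no loss of maximal response. This position therefore holds a group with two aromatic rings as well as one with a single five-membered aromatic ring, while the step from compound 2 to compound 3 cannot be read, so pyridin-3-yl remains unplaced. Nothing measured here accounts for the rise.

Open, from the compounds shown here alone, is whether the rise follows the added ring, the hetero atoms or the size of the group alone; a plain phenyl or naphthyl group on the sulfonyl sulfur would help separate these. Also open, going by these compounds, is whether the same sulfonyl group keeps its response with a change to the ethyl or benzyl group on the amide nitrogen.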